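Lengthening the ester chain of compound 3

The source may report more compounds than this note shows. Statements on the series, on what has been measured and on what is new or still open speak of the compounds shown alone.

Of the compounds shown here, three have been measured in a physicochemical assay for lipophilicity; a lower number here means a more polar compound, a higher number a more lipophilic compound. Compound 3 (`CCOC(=O)c1cccc(S(N)(=O)=O)c1`) stands lowest, at 1.11. Compound 2 (`CCCCCNC(=O)c1ccc(S(N)(=O)=O)cc1`) gives 1.54, and compound 1 (`CCCCCCOC(=O)c1ccc(S(N)(=O)=O)cc1`) gives 3.23. Both of these numbers lie beyond the scatter from that of compound 3.

Compound 4 (`CCCCCOC(=O)c1cccc(S(N)(=O)=O)c1`) carries propyl in place of hydrogen on a saturated chain carbon, two bonds along the chain from an oxygen next to a carbonyl group. The same change reads as ethoxy to pentyloxy. Within the data shown here, no two measured compounds differ in one place only, so the series offers no direct measure of such a step.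

The nearest guide is an ester with a longer chain than compound 4, namely compound 1 at 3.23, although it also differs from compound 3 elsewhere. An upward step beyond the scatter is therefore expected in this assay, estimated as a number 1.54 log units higher from compound 3 to compound 4 (beyond the scatter). For compound 4, the estimated value is 2.65, with an expected range of 2.3 to 3.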

Compound 4, partition coefficient: 2.71
The estimate for compound 4 lay 0.06 log units below the measured number, within the range that was stated.
By their numbers in this assay, from the lowest: compound 3; then compound 2; then compound 4; then compound 1.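

Ethoxy to pentyloxy gives the series its first step that differs in one place only: in this assay the change reads as a number 1.60 log units higher from compound 3 to compound 4 (beyond the scatter) and counts as large. The position on a saturated chain carbon, two bonds along the chain from an oxygen next to a carbonyl group, is thus shown to respond to propyl in place of hydrogen, with the rest of compound 3 left unchanged. Nothing available here bears on why the step has this size.

Going by these compounds, whether the number keeps rising with a longer chain, or moves differently with a branched chain or a chain ending in an amine or a carboxylic acid, remains open. A single step also leaves open whether the same change would give a similar step on the core of compound 1.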